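Dropping the Methyl of Compound 2

The compounds below may be only part of what the source reports. "The series", "measured", "known", "first", "only" and "open" are said of these compounds alone.

Compound 1 `COc1ccc(C(Nc2cc(C)ccn2)c2ccc3cccnc3c2O)cc1O` was tested in an assay for inhibition of protein disulfide-isomerase (Homo sapiens), with a stated time of 1 h (on this read-out lower numbers stand for stronger inhibition and higher numbers for weaker inhibition), where compound 1 gives 150 nM. Compound 2 `Cc1ccnc(NC(c2ccccc2C)c2ccc3cccnc3c2O)c1` gives > 40000 nM in this assay, and that value is a limit of the assay rather than a number (the limit of > 40000 nM in this assay, at which 1 of the 2 values shown sits). Within the data shown here, the single measured step, an at least 260-fold higher number from compound 1 to compound 2 (2.42 log units; beyond the scatter), comes from 2-methylphenyl in place of 3-hydroxy-4-methoxyphenyl on a saturated chain carbon bound to an aromatic carbon and a nitrogen on an aromatic ring. Compound 3 `Cc1ccnc(NC(c2ccccc2)c2ccc3cccnc3c2O)c1` follows from compound 2 by hydrogen in place of methyl on an aromatic carbon, which, cut one bond further out, reads 2-methylphenyl to phenyl. That measured step concerns other groups on the same ring and gives no direction for removing the methyl alone. From the compounds shown here alone, because compound 2 stands at the limit of > 40000 nM in this assay, at which 1 of the 2 values shown sits, its true position is unknown, so no step size can be read against it. Compound 3 is expected to stay weak, with an estimated 25000 nM in this assay, ranging from 4000 nM to 80000 nM. This expectation amounts to an at least 1.6-fold lower number from compound 2 to compound 3 (0.20 log units; that floor lies within the scatter).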

Compound 3, half-maximal inhibitory concentration: < 200 nM
Compound 3: only a limit was reported; the forecaster's own chance of this, stated with the estimate: 50%; at least 120-fold (2.09 log units) between middle value and limit.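

In this assay, a methyl on an aromatic carbon ortho to a large group, a single heavy atom, is enough by itself to decide between a weak and a strong compound, with an at least 200-fold lower number from compound 2 to compound 3 (2.30 log units; beyond the scatter). Compound 3 gives < 200 nM, which is a limit of the assay and not a number: the limit of < 200 nM in this assay, at which 1 of the 3 values shown sits. The step between compound 1 and compound 3 cannot be read, but compound 3 shows that a plain phenyl, without the hydroxy and methoxy groups of compound 1, can still give strong inhibition, so the loss at compound 2 cannot be put down to their absence alone.

From the compounds shown here alone, how far compound 3 lies beyond its limit remains open. So does whether only a methyl has this effect at that place, or whether a chlorine or an amine there would do the same.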